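Furan Back to Thiophene on the Shared Core

The source may report more compounds than this note shows. Statements on the series, on what has been measured and on what is new or still open speak of the compounds shown alone.

Going by the values given here, compound 2 `COc1ncnc2c1c(-c1ccoc1)cn2[C@@H]1O[C@H](CO)[C@@H](O)[C@H]1O` holds the lowest of the two numbers so far: in an ADME assay on MRC5 cells (Homo sapiens), read by MTT assay, with a stated time of 72 h (on this read-out higher numbers stand for weaker inhibition and lower numbers for stronger inhibition), compound 2 gives 29400 nM, while compound 1 `COc1ncnc2c1c(-c1ccsc1)cn2[C@@H]1O[C@H](CO)[C@@H](O)[C@H]1O` gives 75300 nM. Among the compounds with values here, the single measured step, a 2.6-fold lower number from compound 1 to compound 2 (0.41 log units; beyond the scatter), bears directly on the change now considered. Compound 3 `COc1ncnc2c1c(-c1cccs1)cn2[C@@H]1O[C@H](CO)[C@@H](O)[C@H]1O` differs from compound 2 by thiophen-2-yl in place of furan-3-yl on an aromatic carbon. Since a thiophene group returns in place of the furan, the earlier step is expected to be roughly undone, with an estimated change of a 2.0-fold higher number from compound 2 to compound 3 (0.31 log units; beyond the scatter). Compound 3 is therefore expected to give about 60000 nM, within a range from 25000 nM to 150000 nM.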

Compound 3, half-maximal inhibitory concentration: 43200 nM
Compound 3: the middle estimate sits 1.4-fold (0.14 log units) above what was measured; low and high end bracket the measured number.
By their numbers in this assay, from the lowest: compounds 2, 3 and 1 (each within the scatter of the next, the first and the last beyond it).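

In this assay, thiophen-2-yl on this aromatic carbon cannot be told apart from furan-3-yl (a 1.5-fold higher number from compound 2 to compound 3 (0.17 log units; within the scatter)) or from thiophen-3-yl (a 1.7-fold lower number from compound 1 to compound 3 (0.24 log units; within the scatter)). Compound 3 thus lies within the scatter of both neighbours, even though compound 1 and compound 2 stand apart beyond it. Nothing available here accounts for these differences. The compounds shown leave open whether this position tolerates anything other than a five-membered aromatic ring, such as a phenyl ring, an amine or a carboxylic acid. They also leave open how these groups would read in cells other than MRC5.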